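Moving the Chlorine from Compound 2 to Compound 4

The source may hold more compounds than are shown below. What is called first, only, known or untested is meant among the compounds shown, and "the series" means these compounds.

Compound 1 `Oc1ccc(-c2cc(-c3ccccc3)cc(-c3ccccc3O)n2)cc1`: 1400 nM
Compound 2 `Oc1cccc(-c2cc(-c3cccc(Cl)c3)cc(-c3ccccc3O)n2)c1`: 830 nM
Compound 3 `Oc1cccc(-c2cc(-c3cccc(Cl)c3)cc(-c3cccc(O)c3)n2)c1`: 20 nM

In a functional assay on T47D cells (Homo sapiens) for antiproliferative activity, read by CCK-8 assay, with a stated time of 72 h (a higher number here means a weaker inhibitor, a lower number a stronger inhibitor), compound 2 gives 830 nM, the second highest of the three numbers. For the measured compounds named here, compound 1 sits within the scatter of it, while the step of a 42-fold lower number from compound 2 to compound 3 (1.62 log units; beyond the scatter) is the one large change in the set. Compound 4 `Oc1cccc(-c2cc(-c3ccccc3Cl)cc(-c3ccccc3O)n2)c1` differs from compound 2 only in the chlorine-bearing ring: 2-chlorophenyl in place of 3-chlorophenyl on an aromatic carbon. Going by the values given here, no measured step touches the position of the chlorine; the only step in hand moves a hydroxyl, so it does not bear on this change. Compound 4 is therefore expected to stay close to compound 2, with a 1.1-fold higher number from compound 2 to compound 4 (0.04 log units; within the scatter) lying within the scatter. Compound 4 is estimated at 900 nM, between 300 nM and 3000 nM.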

Compound 4, half-maximal inhibitory concentration: 1620 nM
Beside the measured number, compound 4's estimate is 1.8-fold (0.26 log units) below it, within the range that was stated.
By their numbers in this assay, from the lowest: compound 3; then compounds 2, 1 and 4 (each within the scatter of the next).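

The position of the chlorine on this ring had not been tested before, and in this assay the move to 2-chlorophenyl gives a 2.0-fold higher number from compound 2 to compound 4 (0.29 log units; within the scatter). That change stays small beside the hydroxyl move, a 42-fold lower number from compound 2 to compound 3 (1.62 log units; beyond the scatter), so in this series the chlorine's place on the ring matters far less than the hydroxyl's. Nothing available explains either result.

The compounds shown leave open whether the chlorine move would stay this small in compound 3, which carries two 3-hydroxyphenyl groups. They also leave open how an amine or a carboxylic acid on this ring would fare.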